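Acylthiourea series: cytotoxicity on hepatoma cells

The source may hold more compounds than are shown below. What is called first, only, known or untested is meant among the compounds shown, and "the series" means these compounds.

Compound 1 `O=C(NC(=S)N1CCc2c(OCCCCCOc3ccc(Cl)cc3)cccc21)Oc1ccccc1`: in an ADME assay on Huh-7 cells (Homo sapiens) for cytotoxicity (on this read-out lower numbers stand for higher toxicity in this test and higher numbers for lower toxicity in this test), compound 1 gives > 50000 nM, a limit of the assay rather than a number.
Compound 2 `O=C(NC(=S)N1CCc2c(OCCCCCOc3ccc(Cl)cc3)cccc21)c1ccc(C(F)(F)F)cc1`: in this assay compound 2 gives 32700 nM.
Compound 3 `O=C(CCc1ccccc1)NC(=S)N1CCc2c(OCCCCCOc3ccc(Cl)cc3)cccc21`: in this assay compound 3 gives > 50000 nM, again a limit of the assay.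

Compound 3 thus stands at the upper limit of this assay, where compound 1 also sits (the limit of > 50000 nM in this assay, at which 2 of the 3 values shown sit). For the measured compounds named here, the only measured number is that of compound 2, so the step of an at least 1.5-fold higher number from compound 2 to compound 3 (0.18 log units; that floor lies within the scatter) reads only as a floor that lies within the scatter, and the step that the two limits leave unreadable from compound 1 to compound 3 cannot be read at all.

Compound 4 `O=C(NC(=S)N1CCc2c(OCCCCCOc3ccc(Cl)cc3)cccc21)c1cccnc1` differs from compound 3 by pyridin-3-yl in place of phenethyl on a carbonyl carbon. The measured steps that touch this position are the exchange of phenoxy for 4-(trifluoromethyl)phenyl, an at least 1.5-fold lower number from compound 1 to compound 2 (0.18 log units; that floor lies within the scatter), and the exchange of 4-(trifluoromethyl)phenyl for phenethyl, an at least 1.5-fold higher number from compound 2 to compound 3 (0.18 log units; that floor lies within the scatter); both are small, both sit within the scatter, and neither involves pyridin-3-yl. Going by the values given here, no step therefore supports a change beyond the scatter in this assay, although compound 2, the one compound with an aromatic ring directly on the carbonyl carbon, is the only one with a value under the limit.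

For compound 4 the expected step that the limit leaves unreadable from compound 3 to compound 4 is none beyond the scatter. Compound 4 is estimated at 55000 nM, in the range 25000 nM to 120000 nM, with a fair chance that this assay again reports only a limit.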

Compound 4, half-maximal cytotoxic concentration: 11100 nM
Beside the measured number, compound 4's estimate is 5.0-fold (0.70 log units) above it; measured number below the stated range.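

Pyridin-3-yl on the carbonyl carbon gives the first changes at this position that read beyond the scatter in this assay: an at least 4.5-fold lower number from compound 3 to compound 4 (0.65 log units; beyond the scatter), and an at least 4.5-fold lower number from compound 1 to compound 4 (0.65 log units; beyond the scatter). The exchange between two aromatic rings set directly on the carbonyl carbon also moves the read-out, with a 2.9-fold lower number from compound 2 to compound 4 (0.47 log units; beyond the scatter), so having such a ring in this place does not by itself fix the value in this series. The two steps that start from the top of the range give only floors, and their true sizes stay unknown: the limit of > 50000 nM in this assay, at which 2 of the 4 values shown sit.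

Still open, on these data alone, is whether the ring nitrogen of pyridin-3-yl carries these steps, or whether loss of the trifluoromethyl group would be enough; an unsubstituted phenyl on the carbonyl carbon would separate the two readings. Also open, as far as these compounds go, is how a longer chain ending in a pyridine ring would read in this assay, which would show whether the ring must sit directly on the carbonyl carbon.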